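The source may hold more compounds than are shown below. What is called first, only, known or untested is meant among the compounds shown, and "the series" means these compounds.

Measured in a functional assay on a cell-free system (plasma, Oryctolagus cuniculus) for inhibition, with stated times of 5 min, 1 min and 6 min; a higher number here means a weaker inhibitor, a lower number a stronger inhibitor:
- compound 1 `CCOC(=O)c1c(C)nc(-c2cccc(C#N)c2)n1OCC(N)=O`: > 30000 nM
- compound 2 `CCOC(=O)c1c(C)nc(-c2cccc(C#N)c2)n1OCc1ccccc1F`: 8990 nM
- compound 3 `CCOC(=O)c1c(C)nc(-c2cccc(C#N)c2)n1OCc1ccc(Cl)cc1`: 6830 nM

The entry for compound 1 is a limit of the assay and not a number. Compound 3 stands level with compound 2, as the measured 1.3-fold lower number from compound 2 to compound 3 (0.12 log units; within the scatter) shows. Both sit clear of compound 1, seen in an at least 3.3-fold lower number from compound 1 to compound 2 (0.52 log units; beyond the scatter) and an at least 4.3-fold lower number from compound 1 to compound 3 (0.64 log units; beyond the scatter).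

Compound 4 `CCOC(=O)c1c(C)nc(-c2cccc(C#N)c2)n1OCc1ccc(C#N)cc1` differs from compound 3 in one group: cyano in place of chloro on an aromatic carbon. Cyano takes the place of chloro on an aromatic carbon, para to a large group. Going by the values given here, no measured step makes this exact swap. The closest is a 1.3-fold lower number from compound 2 to compound 3 (0.12 log units; within the scatter), which also exchanges one substituted phenyl for another. The larger steps replaced carbamoyl, a different kind of change, so they say less here. In this assay, no change beyond the scatter is therefore expected. The estimate is a 1.0-fold higher number from compound 3 to compound 4 (0.01 log units; within the scatter). For compound 4 the expected value is 7000 nM, with an estimated range of 3000 nM to 16000 nM.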

Compound 4, half-maximal inhibitory concentration: 4240 nM
Estimate against measurement, compound 4: 1.7-fold (0.22 log units) above, within the range that was stated.
By their numbers in this assay, from the lowest: compounds 4, 3 and 2 (each within the scatter of the next, the first and the last beyond it). At a limit, above all of these: compound 1.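

Cyano in place of chloro on this aromatic carbon leaves the result in this assay within the scatter, with a 1.6-fold lower number from compound 3 to compound 4 (0.21 log units; within the scatter), so these two quite different groups cannot be told apart here. Going by these compounds alone, exchanging one substituted phenyl for another can still matter, though modestly: a 2.1-fold lower number from compound 2 to compound 4 (0.33 log units; beyond the scatter) is the first such step to clear the scatter. Against carbamoyl the step reads an at least 7.0-fold lower number from compound 1 to compound 4 (0.84 log units; beyond the scatter), which is a bound and not a true size, set by a limit: the limit of > 30000 nM in this assay, at which 1 of the 4 values shown sits.

Compound 2 and compound 4 differ both in the group and in where it sits on the phenyl, so their step cannot say which of the two matters. From the compounds shown here alone, how an amine or a carboxylic acid would behave on this same carbon also remains open.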